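The source may hold more compounds than are shown below. What is called first, only, known or untested is meant among the compounds shown, and "the series" means these compounds.

Measured compounds:
Compound 1 `COc1ccc(-n2cc(COc3c(/C=C\C(=O)O)ccc(OC)c3CC=C(C)C)nn2)cc1` — in a functional assay on COLO 205 cells (Homo sapiens) for cytotoxicity, read by MTT assay, with a stated time of 24 h (a lower number here means a stronger inhibitor, a higher number a weaker inhibitor), compound 1 gives "not determined" (no result reported).
Compound 2 `COc1ccc(/C=C\C(=O)O)c(OCc2cn(-c3ccc(NC(C)=O)cc3)nn2)c1CC=C(C)C` — compound 2 gives 22600 nM.
Compound 3 `COc1ccc(/C=C\C(=O)O)c(OCc2cn(-c3cccnc3Cl)nn2)c1CC=C(C)C` — compound 3 gives "not determined" (no result reported).

These three compounds share one core and differ only in the group carried on an aromatic nitrogen of the five-membered ring. Of the three, only compound 2 has a number: in this assay compound 2 gives 22600 nM, a weak inhibitor by this read-out. For the measured compounds named here, compound 1 and compound 3 have no number at all, so compound 3 stands nowhere on the scale; nothing measured places it relative to compound 2, and the single result for compound 2 is the only anchor.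

Compound 4 `COc1ccc(/C=C\C(=O)O)c(OCc2cn(-c3ccc(C#N)cc3)nn2)c1CC=C(C)C` is the next member. The change from compound 3 to compound 4 is 4-cyanophenyl in place of 2-chloropyridin-3-yl on an aromatic nitrogen. Going by the values given here, since compound 3 has no result, no step can be computed, and the expectation for compound 4 rests on compound 2 alone, which gives 22600 nM in this assay. Compound 4 is expected to land in the same weak region, with no step beyond the usual scatter from a comparable aryl group.

For compound 4 the estimated value in this assay is 20000 nM, with an expected range of 5000 nM to 80000 nM.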

Compound 4, half-maximal inhibitory concentration: 32000 nM
Compound 4: the middle estimate sits 1.6-fold (0.20 log units) below what was measured; the range from low to high includes it.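

In this assay, the series now has its first step that can be read: cyano in place of acetamido on an aromatic carbon of the aryl group gives a 1.4-fold higher number from compound 2 to compound 4 (0.15 log units; within the scatter). With compound 2 at 22600 nM and compound 4 at 32000 nM, this exchange of an amide-bearing group for a nitrile produces no difference that can be told from the usual variation between repeated measurements, so on this pair the read-out does not depend on which of these two groups sits at that carbon. Nothing shown here bears on why the two compounds read alike.

Compound 1 and compound 3 carry no number, so the change from 2-chloropyridin-3-yl to 4-cyanophenyl cannot be read, and the aryl groups of those two compounds stay unplaced on the scale. On these data alone, it also remains open whether an amine, a carboxylic acid or a longer chain on that same aromatic carbon would shift the number beyond the scatter.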